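A few compounds are considered here, and "the series" means these few. Any claim that something is new, unique, unknown or untested is made for them only; others in the source may bear on it.

Working notes on the series. In a functional assay on HeLa cells (Homo sapiens) for inhibition, read by MTT assay, with a stated time of 72 h (a higher number here means a weaker inhibitor, a lower number a stronger inhibitor), compound 1 (`COc1cc(NC(C)CCCNC(=O)NNC(=O)Nc2ccc(Cl)cc2)c2ncccc2c1`) gives 120000 nM and compound 2 (`COc1cc(NC(C)CCCNC(=O)NNC(=O)Nc2ccc(C(F)(F)F)cc2)c2ncccc2c1`) gives 15000 nM, so compound 2 holds the lower of the two numbers. Compound 3 (`COc1cc(NC(C)CCCNC(=O)NNC(=O)Nc2cccc(F)c2)c2ncccc2c1`) is not yet measured and differs from compound 2 as follows: 3-fluorophenyl in place of 4-(trifluoromethyl)phenyl on an amide-type nitrogen. In words, this is 3-fluorophenyl in place of 4-(trifluoromethyl)phenyl on an amide-type nitrogen. Going by the values given here, the one measured step bearing on this change is an 8.0-fold lower number from compound 1 to compound 2 (0.90 log units; beyond the scatter), with trifluoromethyl in place of chloro on an aromatic carbon. Among the compounds with values here, no measured compound carries 3-fluorophenyl, so this single step is a weak guide. A step of similar or smaller size towards a higher number is expected in this assay, since compound 3 lacks the trifluoromethyl of compound 2. The estimated step is a 2.7-fold higher number from compound 2 to compound 3 (0.43 log units; beyond the scatter). For compound 3 the estimated value is 40000 nM, with an expected range of 12000 nM to 130000 nM.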

Compound 3, half-maximal inhibitory concentration: > 250000 nM
Compound 3 was reported as a limit; the forecaster's own chance of this, stated with the estimate: 15%; at least 6.2-fold (0.79 log units) between middle value and limit.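

In this assay the value of compound 3 is a limit and not a number: the limit of > 250000 nM in this assay, at which 1 of the 3 values shown sits.

The change on the amide-type nitrogen gives an at least 16-fold higher number from compound 2 to compound 3 (1.22 log units; beyond the scatter), and the comparison with the chloro analogue gives an at least 2.0-fold higher number from compound 1 to compound 3 (0.31 log units; beyond the scatter). The earlier compounds shown here showed only a difference between two 4-substituted phenyl groups, whereas the three now rank 4-(trifluoromethyl)phenyl, 4-chlorophenyl and 3-fluorophenyl from the lowest number to the highest, so the aryl group on this nitrogen can also take the series upwards to the limit of the assay.

The 3-fluorophenyl group differs from the other two groups in both its substituent and where that substituent stands, and the compounds shown do not separate these two changes. On these data alone, what a 4-fluorophenyl or a 3-(trifluoromethyl)phenyl group would give on this nitrogen remains open.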